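This account rests on a few compounds, and the source may have more. Where it says the series, first, only, none or still open, it means among the compounds named here.

Among the compounds with values here, in a toxicity assay on NIH3T3 cells (Mus musculus) for cytotoxicity, read by resazurin assay (a higher number here means that more compound is needed for the effect, a lower number that less compound is needed), compound 1 `COC(=O)c1ccc(NCc2cncn2Cc2ccc(Cl)cc2)cc1-c1ccccc1` gives 25000 nM, the only exact number so far. For compound 2 `CC(=O)c1ccc(NCc2cncn2Cc2ccc(-c3ccccc3)cc2)cc1-c1ccccc1` the reading is > 10000 nM, which is a limit and not a number. The two therefore cannot be ranked against each other.

Compound 3 `COC(=O)c1ccc(NCc2cncn2Cc2cccc(Br)c2)cc1-c1ccccc1` keeps the core of compound 1 and changes one group: 3-bromophenyl in place of 4-chlorophenyl on a saturated chain carbon bound to an aromatic nitrogen. In words, 3-bromophenyl stands in place of 4-chlorophenyl on a saturated chain carbon bound to an aromatic nitrogen. Within the data shown here, no measured pair of compounds shows what such a swap does, so the expectation starts from compound 1 at 25000 nM, and no change beyond the usual scatter is expected in this assay. The expected step, a 1.1-fold lower number from compound 1 to compound 3 (0.06 log units; within the scatter), is therefore small and has no firm direction. For compound 3 the estimate is 22000 nM, with an expected range from 10000 nM to 50000 nM.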

Compound 3, half-maximal effective concentration: > 10000 nM
Compound 3: a limit, no number (the forecaster's own chance of this, stated with the estimate: 25%); the middle value is on the limit's open side.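

In this assay compound 3 gives > 10000 nM, which is a limit and not a number. Within the data shown here, no step from compound 1 to compound 3 can be read. Whether 3-bromophenyl in place of 4-chlorophenyl changes the reading at all stays open, because most values shown stop at one limit: the limit of > 10000 nM in this assay, at which 2 of the 3 values shown sit.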